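Swapping hydroxy for acetylsulfanyl on a cyclic peptide series

This account rests on a few compounds, and the source may have more. Where it says the series, first, only, none or still open, it means among the compounds named here.

Compound 3 `COc1ccc(C[C@H]2C(=O)N[C@@H](C)C(=O)N(C)[C@H]3Cc4ccc(cc4)Oc4cc(ccc4OC)C[C@@H](C(=O)N[C@H](C)C(=O)N[C@@H](CO)C(=O)N2C)N(C)C3=O)cc1` gives 14.1 nM in a functional assay on P388 cells (Mus musculus) for cytotoxicity (on this read-out lower numbers stand for stronger inhibition and higher numbers for weaker inhibition), and holds the lowest number of the three measured compounds. Its closest neighbour is compound 2 `COC(=O)C[C@@H]1NC(=O)[C@@H](C)NC(=O)[C@@H]2Cc3ccc(OC)c(c3)Oc3ccc(cc3)C[C@@H](C(=O)N2C)N(C)C(=O)[C@H](C)NC(=O)[C@H](Cc2ccc(OC)cc2)N(C)C1=O`, which gives 41.7 nM, and the furthest is compound 1 `COc1ccc(C[C@H]2C(=O)N[C@@H](C)C(=O)N(C)[C@H]3Cc4ccc(cc4)Oc4cc(ccc4OC)C[C@@H](C(=O)N[C@H](C)C(=O)N[C@@H](CCC(=O)O)C(=O)N2C)N(C)C3=O)cc1`, which gives 219 nM. Both measured steps that end at compound 3 point the same way: a 16-fold lower number from compound 1 to compound 3 (1.19 log units; beyond the scatter) and a 3.0-fold lower number from compound 2 to compound 3 (0.47 log units; beyond the scatter), so every replacement of another group at this position by hydroxy lowered the number beyond the scatter.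

Compound 4 `COc1ccc(C[C@H]2C(=O)N[C@@H](C)C(=O)N(C)[C@H]3Cc4ccc(cc4)Oc4cc(ccc4OC)C[C@@H](C(=O)N[C@H](C)C(=O)N[C@@H](CSC(C)=O)C(=O)N2C)N(C)C3=O)cc1` differs from compound 3 as follows: acetylsulfanyl in place of hydroxy on a saturated chain carbon bound to a saturated ring carbon. Within the data shown here, no measured step covers acetylsulfanyl itself, so the expectation must rest on the two steps above, read in reverse. Leaving hydroxy for carboxymethyl cost a large step and leaving it for methoxycarbonyl a modest one; a modest rise is therefore expected for compound 4, in the direction of a higher number, as in a 2.8-fold higher number from compound 3 to compound 4 (0.45 log units; beyond the scatter). The estimate for compound 4 in this assay is 40 nM, with a range from 12 nM to 130 nM.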

Compound 4, half-maximal inhibitory concentration: 9.77 nM
Compound 4: middle estimate off by 4.1-fold (0.61 log units), on the high side; measured number below the stated range.
By their numbers in this assay, from the lowest: compounds 4 and 3 (each within the scatter of the next); then compound 2; then compound 1.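

In this assay, acetylsulfanyl on this saturated chain carbon bound to a saturated ring carbon stays level with hydroxy, with a 1.4-fold lower number from compound 3 to compound 4 (0.16 log units; within the scatter), so the hydrogen-bond donor of hydroxy is not needed to reach this range, and a group of 4 heavy atoms fits there too. Acetylsulfanyl also stands clear of the other two groups, with a 4.3-fold lower number from compound 2 to compound 4 (0.63 log units; beyond the scatter) and a 22-fold lower number from compound 1 to compound 4 (1.35 log units; beyond the scatter), so the higher numbers seen with methoxycarbonyl and carboxymethyl do not follow simply from leaving hydroxy. No accompanying measurement explains these differences.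

The compounds shown leave open whether the sulfur or the acetyl part of acetylsulfanyl matters at this position. A free thiol or an acetoxy group would separate the two, and an amine would test a further kind of group there.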